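From an Aryl Sulfone to a Difluorocyclohexyl Sulfone

The source may hold more compounds than are shown below. What is called first, only, known or untested is meant among the compounds shown, and "the series" means these compounds.

Of the compounds shown here, three have so far been measured in an assay on isolated protein for inhibition of Nicotinamide phosphoribosyltransferase (Homo sapiens), read by mass spectrometry, with stated times of 15 min and 30 min; a lower number here means a stronger inhibitor, a higher number a weaker inhibitor. Compound 1 `O=C(NCc1ccc(S(=O)(=O)c2ccccc2)cc1)N1Cc2cccnc2C1` gives 60 nM in this assay, compound 2 `O=C(NCc1ccc(S(=O)(=O)c2ccccc2)cc1)N1CCc2ccncc2C1` gives 310 nM, and compound 3 `O=C(NCc1ccc(S(=O)(=O)c2cncc(C(F)(F)F)c2)cc1)N1Cc2ccncc2C1` gives 15 nM. Compound 3 therefore stands at the lowest number of the three, and its gaps to compound 1 and to compound 2 both lie beyond the usual scatter, so it is the strongest inhibitor measured to date.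

Compound 4 `O=C(NCc1ccc(S(=O)(=O)C2CCC(F)(F)CC2)cc1)N1Cc2ccncc2C1` has not yet been measured. It differs from compound 3 in one place: 4,4-difluorocyclohexyl in place of 5-(trifluoromethyl)pyridin-3-yl on a sulfonyl sulfur. Going by the values given here, no pair of measured compounds shows an exchange of this kind, so there is no directly comparable step in this assay to lean on, and the expectation rests on the change itself. The expected step of a 2.7-fold higher number from compound 3 to compound 4 (0.43 log units; beyond the scatter) is toward a higher number and of modest size, perhaps not far beyond the scatter. Compound 4 is thus estimated at 40 nM, with a range from 10 nM to 150 nM.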

Compound 4, half-maximal inhibitory concentration: 78 nM
Compound 4: the middle estimate sits 2.0-fold (0.29 log units) below what was measured; the range from low to high includes it.
By their numbers in this assay, from the lowest: compound 3; then compounds 1 and 4 (each within the scatter of the next); then compound 2.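

In this assay, the exchange of 5-(trifluoromethyl)pyridin-3-yl for 4,4-difluorocyclohexyl on the sulfonyl sulfur gives a 5.2-fold higher number from compound 3 to compound 4 (0.72 log units; beyond the scatter), and this step is beyond the scatter. An aromatic ring is therefore not required at this place for inhibition, although compound 4 gives a higher number than compound 3. The ring, its nitrogen and its fluorinated substituent all change in this one step, and nothing measured here explains the shift.

The compounds shown leave open how much of the step belongs to each of those changes, which a plain cyclohexyl or a 3-pyridyl without the trifluoromethyl group could help to separate. They also leave open whether a tetrahydropyran-4-yl or a piperidin-4-yl ring would be accepted on the sulfonyl sulfur.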